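A Chloro for a Trifluoromethyl in a Urea Series

The compounds below may be only part of what the source reports. "The series", "measured", "known", "first", "only" and "open" are said of these compounds alone.

Of the compounds shown here, three sharing one core have been measured in a functional assay on MOLT-4 cells (Homo sapiens) for inhibition, read by sulforhodamine B assay, with a stated time of 48 h, tested at 1 uM; a higher number here means a weaker effect of the compound at the concentration tested, a lower number a stronger effect. Compound 1 `O=C(Nc1cccc(-n2cc(-c3ccncc3)c(-c3cc(O)cc(Cl)c3)n2)c1)Nc1ccc(Cl)c(C(F)(F)F)c1` gives 52% in this assay. Compound 2 `O=C(Nc1cccc(-n2cc(-c3ccncc3)c(-c3cc(O)cc(Cl)c3)n2)c1)Nc1ccc(Cl)c(Cl)c1` gives 84%. Compound 3 `COc1cc(Cl)cc(-c2nn(-c3cccc(NC(=O)Nc4ccc(Cl)c(C(F)(F)F)c4)c3)cc2-c2ccncc2)c1` gives 58%, which is the second highest of the three numbers; it sits within the scatter of compound 1 and well apart from compound 2. Among the compounds with values here, the one measured step between compound 1 and compound 3 is small: a number 6 percentage points higher from compound 1 to compound 3 (within the scatter).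

Compound 4 `COc1cc(Cl)cc(-c2nn(-c3cccc(NC(=O)Nc4ccc(Cl)c(Cl)c4)c3)cc2-c2ccncc2)c1` is not yet measured. It differs from compound 3 in one place: chloro in place of trifluoromethyl on an aromatic carbon. The same exchange has already been seen once, between compound 1 and compound 2, where it gave a number 32 percentage points higher from compound 1 to compound 2 (beyond the scatter). Within the data shown here, that single step is the only direct guide here, so a step of similar size and in the same direction, toward a weaker effect, is expected for a number 30 percentage points higher from compound 3 to compound 4 (beyond the scatter). On that basis compound 4 is estimated at 88% in this assay, with a likely range from 72% to 100%.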

Compound 4, a percentage reported as activity, at one concentration (the size of the read-out at that concentration, not a potency): 70%
Beside the measured number, compound 4's estimate is 18 percentage points above it, outside the stated range (below it).
By their numbers in this assay, from the lowest: compounds 1 and 3 (each within the scatter of the next); then compound 4; then compound 2.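

Exchanging trifluoromethyl for chloro on this aromatic carbon weakens the effect in this assay on both cores, but the size of the loss depends on what sits on the oxygen of the other aryl group, and with the methyl in place a number 12 percentage points higher from compound 3 to compound 4 (beyond the scatter), a much smaller step: the same change on two cores in this assay, a number 32 percentage points higher (beyond the scatter) from compound 1 to compound 2 and a number 12 percentage points higher (beyond the scatter) from compound 3 to compound 4, 20 percentage points apart, beyond the scatter of two such steps. The methyl on that oxygen also proves not to be neutral, since with 3,4-dichlorophenyl on the urea a number 14 percentage points lower from compound 2 to compound 4 (beyond the scatter), a strengthening not seen with the trifluoromethyl group present: the same change on two cores in this assay, a number 6 percentage points higher (within the scatter) from compound 1 to compound 3 and a number 14 percentage points lower (beyond the scatter) from compound 2 to compound 4, 20 percentage points apart, beyond the scatter of two such steps. Across these four compounds, then, the two changes do not act independently of each other.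

At this position the compounds shown hold only trifluoromethyl and chloro, so how a nitrile or a bromo would read there stays open. On these data alone, whether an ethyl on the oxygen would go further than the methyl is equally open.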